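This account rests on a few compounds, and the source may have more. Where it says the series, first, only, none or still open, it means among the compounds named here.

Measured so far in an ADME assay on MT2 cells (Homo sapiens) for cytotoxicity, read by XTT assay, with a stated time of 4 days; on this read-out higher numbers stand for lower toxicity in this test and lower numbers for higher toxicity in this test:
compound 1 `Cc1cc(/C=C2\SC(=S)N(Cc3ccc(Br)cc3)C2=O)c(C)n1-c1ccc(O)c(C(=O)O)c1` gives 94400 nM
compound 2 `COC(=O)c1cccc(CN2C(=O)/C(=C/c3cc(C)n(-c4ccc(O)c(C(=O)O)c4)c3C)SC2=S)c1` gives 38500 nM

Compound 1 holds the higher of the two numbers in this assay; its nearest neighbour is compound 2, reached by a 2.5-fold lower number from compound 1 to compound 2 (0.39 log units; beyond the scatter). Compound 3 `Cc1cc(/C=C2\SC(=S)N(Cc3cccc(C(=O)O)c3)C2=O)c(C)n1-c1ccc(O)c(C(=O)O)c1` has not yet been measured in this assay. It differs from compound 1 in a single place: 3-carboxyphenyl in place of 4-bromophenyl on a saturated chain carbon bound to an amide-type nitrogen in a ring. Within the data shown here, the only measured step that touches this place is a 2.5-fold lower number from compound 1 to compound 2 (0.39 log units; beyond the scatter), where 3-(methoxycarbonyl)phenyl took the place of the same 4-bromophenyl on the same saturated chain carbon, and that step was modest. Among the measured compounds shown here, the 3-carboxyphenyl group of compound 3 appears in none of the measured compounds, so the data give no direct precedent for it. On that basis a step of about a 1.3-fold lower number from compound 1 to compound 3 (0.10 log units; within the scatter) is expected, small and possibly within the scatter. The estimate for compound 3 in this assay is 75000 nM, with a range from 30000 nM to 190000 nM.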

Compound 3, half-maximal cytotoxic concentration: > 100000 nM
Compound 3: only a limit was reported; the forecaster's own chance of this, stated with the estimate: 25%; middle value at least 1.3-fold (0.12 log units) away from the limit.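

In this assay, compound 3 gives a limit and not a number: the limit of > 100000 nM in this assay, at which 1 of the 3 values shown sits. Replacing 4-bromobenzyl with 3-carboxybenzyl gives an at least 1.0-fold higher number from compound 1 to compound 3 (0.02 log units; that floor lies within the scatter), so this change cannot be separated from compound 1 on the floor alone. The new information lies in the comparison with the ester, where 3-carboxyphenyl in place of 3-(methoxycarbonyl)phenyl gives an at least 2.5-fold higher number from compound 2 to compound 3 (0.41 log units; beyond the scatter), showing that the lower number of compound 2 does not carry over to the carboxylic acid.

The limit leaves open how far compound 3 actually stands from compound 1, or whether the two differ at all. Also open, as far as these compounds go, is how a phenyl bearing an amine, or a longer chain carrying the carboxylic acid, would read in this assay at this place on the shared core.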